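A few compounds are considered here, and "the series" means these few. Any claim that something is new, unique, unknown or untested is made for them only; others in the source may bear on it.

The study compares two measured compounds and one that awaits measurement. Compound 1, `COc1ccc(-c2noc(-c3cccnc3)n2)cc1OC1CCCC1`, was tested in a functional assay on LNCaP cells (Homo sapiens) for antiproliferative activity, read by MTT assay, with a stated time of 24 h; on this read-out higher numbers stand for weaker inhibition and lower numbers for stronger inhibition. In this assay compound 1 gives only a limit of the assay, > 1000000 nM, and not a number. Compound 2, `COc1ccc(-c2noc(C3CCNCC3)n2)cc1OC1CCCC1`, gives 10 nM in this assay. Among the compounds with values here, compound 2 therefore stands as the only numerical value shown, the other value being the limit (the limit of > 1000000 nM in this assay, at which 1 of the 2 values shown sits).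

Compound 3, `COc1ccc(-c2noc(-c3ccc(O)cc3)n2)cc1OC1CCCC1`, differs from compound 2 by 4-hydroxyphenyl in place of piperidin-4-yl on an aromatic carbon. Within the data shown here, one measured step bears on this change: from compound 1 to compound 2 a six-membered aromatic ring gave way to a six-membered non-aromatic ring with one hetero atom at the same place, with the very large gain an at least 100000-fold lower number from compound 1 to compound 2 (5.00 log units; beyond the scatter). Compound 3 restores a six-membered aromatic ring of carbon only at that place, so a large step in the opposite direction in this assay is expected, although 4-hydroxyphenyl keeps one hydrogen-bond donor and one hydrogen-bond acceptor. Compound 3 is estimated at 100000 nM, between 1000 nM and 1000000 nM. The expected step is a 10000-fold higher number from compound 2 to compound 3 (4.00 log units; beyond the scatter).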

Compound 3, half-maximal inhibitory concentration: 860 nM
For compound 3 the middle estimate is 120-fold (2.07 log units) above the measured one; measured number outside the range, below it.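

In this assay, a six-membered aromatic ring of carbon only at this place on the five-membered ring does not remove the activity, though it does not match piperidin-4-yl: the change to 4-hydroxyphenyl gives an 86-fold higher number from compound 2 to compound 3 (1.93 log units; beyond the scatter). Two six-membered aromatic rings at the same place also part widely, with 4-hydroxyphenyl in place of pyridin-3-yl giving an at least 1100-fold lower number from compound 1 to compound 3 (3.06 log units; beyond the scatter), so aromatic character alone does not settle the outcome at this position among these compounds. The size of that second step stays open at one end, as the value of compound 1 is a limit of the assay and not a number: the limit of > 1000000 nM in this assay, at which 1 of the 3 values shown sits.

The compounds shown leave open whether the advantage of piperidin-4-yl rests on its ring nitrogen or on the non-aromatic ring itself, and a cyclohexyl ring at this place would speak to that. They also leave open what the hydroxyl of 4-hydroxyphenyl contributes, which an unsubstituted phenyl ring or a 4-aminophenyl group at the same place would help to separate from the contribution of the ring.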